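From 1H-imidazol-1-yl to dimethylamino in compound 2

The compounds below may be only part of what the source reports. "The series", "measured", "known", "first", "only" and "open" are said of these compounds alone.

compound 1 `CCc1nccn1CC#CCN1CCCC1=O`: 2.5 mg/kg
compound 2 `CC1CCC(=O)N1CC#CCn1ccnc1`: 1.1 mg/kg
compound 3 `Cc1cncn1CC#CCN1C(=O)CCC1C`: 1.4 mg/kg

In a functional assay on the whole organism for antagonist activity, with Mus musculus as the target (on this read-out lower numbers stand for an effect already at smaller amounts and higher numbers for an effect only at larger amounts of compound), compound 2 gives 1.1 mg/kg. That value cannot be told apart from compound 3, while compound 1 shows a higher number than compound 2, with the gap beyond the scatter.

Compound 4 `CC1CCC(=O)N1CC#CCN(C)C` differs from compound 2 in one place, with dimethylamino in place of 1H-imidazol-1-yl on a saturated chain carbon bound to a triple-bonded carbon.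

Among the compounds with values here, only one measured step bears on this, a 1.3-fold higher number from compound 2 to compound 3 (0.10 log units; within the scatter). It is methyl in place of hydrogen on an aromatic carbon, and it keeps the five-membered aromatic ring that compound 4 gives up. Within the data shown here, no measured step removes that ring, so the guidance is weak and the range must stay wide. A moderate move towards a higher number is expected in this assay, and the estimated step is a 2.7-fold higher number from compound 2 to compound 4 (0.44 log units; beyond the scatter). Compound 4 is estimated at 3 mg/kg, with an expected range of 0.7 mg/kg to 12 mg/kg.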

Compound 4, dose for half-maximal effect: > 100 mg/kg
Compound 4: no number, only a limit; the forecaster's own chance of this, stated with the estimate: 15%; middle value at least 33-fold (1.52 log units) from the limit.
By their numbers in this assay, from the lowest: compounds 2, 3 and 1 (each within the scatter of the next, the first and the last beyond it). At a limit, above all of these: compound 4.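

In this assay, replacing 1H-imidazol-1-yl with dimethylamino on a saturated chain carbon bound to a triple-bonded carbon gives an at least 90-fold higher number from compound 2 to compound 4 (1.95 log units; beyond the scatter), whereas methyl in place of hydrogen on an aromatic carbon had given only a 1.3-fold higher number from compound 2 to compound 3 (0.10 log units; within the scatter). Within the data shown here, the earlier step left the five-membered aromatic ring in place, so this is the first result to show that the group at this position can decide the outcome, and that the change can be large. Compound 4 has no number, only a limit: the limit of > 100 mg/kg in this assay, at which 1 of the 4 values shown sits.

The compounds shown leave open how far beyond that limit compound 4 lies, and whether the outcome turns on losing the aromatic ring or on the dimethylamino group itself. Pyrrolidin-1-yl or 1H-pyrazol-1-yl at the same place could tell these two readings apart.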